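Turning the chlorobenzyl group on compound 3's core

This account rests on a few compounds, and the source may have more. Where it says the series, first, only, none or still open, it means among the compounds named here.

Measured compounds:
compound 1 `Cc1cc(S(=O)(=O)/N=C(\N)n2nccc2-c2ccccc2)c(SCc2ccc(Cl)cc2)cc1Cl`: 75000 nM
compound 2 `Cc1cc(S(=O)(=O)/N=C(\N)n2nccc2-c2ccccc2)c(SCc2ccccc2Cl)cc1Cl`: 24000 nM
compound 3 `Cc1cc(-c2ccccc2)n(/C(N)=N/S(=O)(=O)c2cc(C)c(Cl)cc2SCc2ccccc2Cl)n1`: 135000 nM

In a functional assay on MCF7 cells (Homo sapiens) for cytotoxicity, read by MTT assay, with a stated time of 72 h (on this read-out lower numbers stand for stronger inhibition and higher numbers for weaker inhibition), compound 3 gives the highest number of the three. Compound 1 sits within the scatter of it, while compound 2 lies clearly lower, as a 5.6-fold higher number from compound 2 to compound 3 (0.75 log units; beyond the scatter) shows.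

Compound 4 `Cc1cc(-c2ccccc2)n(/C(N)=N/S(=O)(=O)c2cc(C)c(Cl)cc2SCc2ccc(Cl)cc2)n1` differs from compound 3 only in the chlorobenzyl group: 4-chlorophenyl in place of 2-chlorophenyl on a saturated chain carbon bound to a sulfur. Among the compounds with values here, one measured step bears on this change directly, run in the opposite direction: a 3.1-fold lower number from compound 1 to compound 2 (0.49 log units; beyond the scatter). Reversing that swap on the core of compound 3 would be expected to move the number up by a similar modest amount in this assay. The step of a 5.6-fold higher number from compound 2 to compound 3 (0.75 log units; beyond the scatter) concerns a different position and does not speak to the swap itself, so the expectation rests on a single pair.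

Compound 4 is therefore expected to give 350000 nM, with a range of 120000 nM to 1000000 nM. The expected step is a 2.6-fold higher number from compound 3 to compound 4 (0.41 log units; beyond the scatter), upward, beyond the scatter, though a number this high may only be reported as a limit.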

Compound 4, half-maximal inhibitory concentration: 108000 nM
Estimate against measurement, compound 4: 3.2-fold (0.51 log units) above; the whole stated range lies above it.
By their numbers in this assay, from the lowest: compound 2; then compounds 1, 4 and 3 (each within the scatter of the next).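

this assay gives a different answer on this second core: the change from 2-chlorobenzyl to 4-chlorobenzyl now yields a 1.3-fold lower number from compound 3 to compound 4 (0.10 log units; within the scatter), so this position does not respond alike on the two cores: the same change on two cores in this assay, a 3.1-fold lower number (0.49 log units; beyond the scatter) from compound 1 to compound 2 and a 1.3-fold higher number (0.10 log units; within the scatter) from compound 4 to compound 3, 3.9-fold (0.59 log units) apart, beyond the scatter of two such steps The methyl in place of hydrogen on an aromatic carbon likewise depends on its partner, since with 4-chlorobenzyl it yields a 1.4-fold higher number from compound 1 to compound 4 (0.16 log units; within the scatter): the same change on two cores in this assay, a 5.6-fold higher number (0.75 log units; beyond the scatter) from compound 2 to compound 3 and a 1.4-fold higher number (0.16 log units; within the scatter) from compound 1 to compound 4, 3.9-fold (0.59 log units) apart, beyond the scatter of two such steps The two changes therefore do not add independently, and the lower number of compound 2 belongs to the combination of 2-chlorobenzyl with hydrogen on that aromatic carbon, set against its two single-change neighbours, compound 1 and compound 3.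

The compounds shown leave open whether this dependence holds for a fluorine or a methoxy group in place of the chlorine. They also leave open what a longer chain between the sulfur and the chlorophenyl would do on either core.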